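The compounds below may be only part of what the source reports. "The series", "measured", "known", "first", "only" and "open" are said of these compounds alone.

In a functional assay on A549 cells (Homo sapiens) for cytotoxicity, read by MTT assay, with a stated time of 72 h (a lower number here means a stronger inhibitor, a higher number a weaker inhibitor), compound 1 `COc1cc2c(Oc3ccc(NC(=O)/C=C/S(=O)(=O)c4ccc(C)cc4)cc3F)ccnc2cc1OCCCN1CCN(C)CC1` gives 1510 nM and compound 2 `COc1ccc(S(=O)(=O)/C=C/C(=O)Nc2ccc(Oc3ccnc4cc(OCCCN5CCCCC5)c(OC)cc34)c(F)c2)cc1` gives 2220 nM. Of these two numbers compound 2 has the higher one, but the gap to compound 1 lies within the usual scatter, so the two read alike. Compound 3 `COc1cc2c(Oc3ccc(NC(=O)/C=C/S(=O)(=O)c4ccc(C)cc4)cc3F)ccnc2cc1OCCCN1CCCCC1` is compound 2 with one change: methyl in place of methoxy on an aromatic carbon. Compound 1 carries this same methyl group and sits within the scatter of compound 2, so no shift beyond the scatter is expected for the step of a 1.2-fold lower number from compound 2 to compound 3 (0.09 log units; within the scatter). Compound 3 is therefore estimated at 1800 nM in this assay, with a likely range from 700 nM to 4500 nM.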

Compound 3, half-maximal inhibitory concentration: 2310 nM
Compound 3: middle estimate off by 1.3-fold (0.11 log units), on the low side, within the range that was stated.
By their numbers in this assay, from the lowest: compounds 1, 2 and 3 (each within the scatter of the next).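

In this assay, each end of the molecule now has a pair that differs in one place. Going from 4-methoxyphenyl to 4-methylphenyl gives a 1.0-fold higher number from compound 2 to compound 3 (0.02 log units; within the scatter), and piperidin-1-yl in place of 4-methylpiperazin-1-yl on the chain gives a 1.5-fold higher number from compound 1 to compound 3 (0.18 log units; within the scatter), so neither single change moves the number beyond the scatter. No other evidence bears on these results. The compounds shown leave open whether a larger change would register, such as a carboxylic acid in place of the methyl on this ring, or a morpholine on the chain.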